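Adding bromo to compound 3

The source may hold more compounds than are shown below. What is called first, only, known or untested is meant among the compounds shown, and "the series" means these compounds.

Compound 1 `CN(C)CCCNc1nc2cc([N+](=O)[O-])ccc2nc1NCc1ccc(C(F)(F)F)cc1` gives 5.66 ug/mL
Compound 2 `CN1CCN(c2nc3cc([N+](=O)[O-])ccc3nc2NCc2ccc(C(F)(F)F)cc2)CC1` gives 6.99 ug/mL
Compound 3 `CN(C)CCCNc1nc2cc([N+](=O)[O-])ccc2nc1NCc1ccccc1` gives 2.74 ug/mL

In an ADME assay on HEK293 cells (Homo sapiens) for cytotoxicity, read by MTT assay, with a stated time of 24 h (on this read-out higher numbers stand for weaker inhibition and lower numbers for stronger inhibition), compound 3 has the lowest number of the three at 2.74 ug/mL and both other compounds lie above it beyond the scatter. Compound 4 `CN(C)CCCNc1nc2cc([N+](=O)[O-])ccc2nc1NCc1ccc(Br)cc1` differs from compound 3 by bromo in place of hydrogen on an aromatic carbon and the change is bromo in place of hydrogen on an aromatic carbon, para to a large group, turning benzyl into 4-bromobenzyl.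

Among the measured compounds shown here, no measured compound carries bromo, so the evidence is indirect. The nearest measured step is a 2.1-fold lower number from compound 1 to compound 3 (0.32 log units; beyond the scatter) and it replaces trifluoromethyl with hydrogen on an aromatic carbon. Read backwards, this single modest step suggests a somewhat higher number once hydrogen gives way to a larger group. The other step of a 1.2-fold higher number from compound 1 to compound 2 (0.09 log units; within the scatter) concerns a different change and says little here. The expected result is therefore a modest rise, namely a 1.6-fold higher number from compound 3 to compound 4 (0.22 log units; within the scatter) with real uncertainty about its size. In this assay the estimate for compound 4 is 4.5 ug/mL with an expected range from 2.4 ug/mL to 8.5 ug/mL as its bounds.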

Compound 4, half-maximal inhibitory concentration: 9.63 ug/mL
For compound 4 the middle estimate is 2.1-fold (0.33 log units) below the measured one; the whole stated range lies below it.
By their numbers in this assay, from the lowest: compound 3; then compounds 1, 2 and 4 (each within the scatter of the next).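

In this assay, the step of a 3.5-fold higher number from compound 3 to compound 4 (0.55 log units; beyond the scatter) shows that bromo on this aromatic carbon, para to a large group, goes with a clearly higher number than hydrogen, as trifluoromethyl did in a 2.1-fold lower number from compound 1 to compound 3 (0.32 log units; beyond the scatter). Bromo and trifluoromethyl are not separated at this position, for the exchange gives a 1.7-fold higher number from compound 1 to compound 4 (0.23 log units; within the scatter), so two different groups now stand on the same side of hydrogen. Nothing available here accounts for this rise with either group.

Going by these compounds, whether fluoro, methoxy or a carboxylic acid at this place would also sit above hydrogen remains open. So does whether bromo would give a similar step on a compound carrying 4-methylpiperazin-1-yl, as compound 2 does, in place of the (3-(dimethylamino)propyl)amino chain.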